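Swapping the Side Chain on the Core of Compound 1

The source may report more compounds than this note shows. Statements on the series, on what has been measured and on what is new or still open speak of the compounds shown alone.

Compound 1, `NCCn1ncc2c(NCc3ccccc3[N+](=O)[O-])cc(C(F)(F)F)cc21`, gives 30% in an assay for inhibition of Indoleamine 2,3-dioxygenase 1 (Homo sapiens), with stated times of 10 min and 60 min, tested at 100 uM; a higher number here means a stronger effect of the compound at the concentration tested, a lower number a weaker effect.
Compound 2, `O=C1NCc2c(NCc3ccccc3[N+](=O)[O-])cccc21`, gives 9% in this assay.

Compound 1 stands highest of the two numbers. Compound 2 is the nearest, and its value lies lower by a gap beyond the usual scatter. The two share only part of their structure, so this gap cannot be traced to a single change.

Compound 3, `CC(C)n1ncc2c(NCc3ccccc3[N+](=O)[O-])cc(C(F)(F)F)cc21`, is not yet measured. It differs from compound 1 in one place: isopropyl in place of 2-aminoethyl on an aromatic nitrogen. Among the measured compounds shown here, no pair of measured compounds shows how such a change plays out, so the expectation rests on compound 1 alone. For compound 3 a small decrease is expected, a number 6 percentage points lower from compound 1 to compound 3 (within the scatter), though a step within the scatter is nearly as plausible. Compound 3 is estimated at 24%, with a range from 5% to 45%.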

Compound 3, a percentage reported as inhibition, at one concentration (the size of the read-out at that concentration, not a potency): 13%
The estimate for compound 3 lay 11 percentage points above the measured number; the range from low to high includes it.
By their numbers in this assay, from the lowest: compounds 2 and 3 (each within the scatter of the next); then compound 1.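

In this assay, among the compounds shown here, putting isopropyl in place of 2-aminoethyl on the aromatic nitrogen gives a number 17 percentage points lower from compound 1 to compound 3 (beyond the scatter) and so shows, through the first comparison that differs in one place, that the number responds to the group at this position. Both groups have the same count of heavy atoms, but isopropyl has no nitrogen and no hydrogen-bond donor or acceptor, so the step comes from a change in the kind of atoms and not in their number. No measurement at hand explains why the number falls.

Still open, going by these compounds, is whether the nitrogen of the side chain itself matters, which a 2-hydroxyethyl group or a longer 3-aminopropyl chain on the same aromatic nitrogen could test. This single step also leaves open whether the same change would act alike on another core.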